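Working notes: pyrimidinyl to trifluoromethylpyridinyl on compound 3

The source may hold more compounds than are shown below. What is called first, only, known or untested is meant among the compounds shown, and "the series" means these compounds.

Among the measured compounds shown here, in a toxicity assay on MT4 cells (Homo sapiens) for cytotoxicity, read by MTT assay, with a stated time of 5 days (on this read-out lower numbers stand for higher toxicity in this test and higher numbers for lower toxicity in this test), compound 3 `Cc1cc(-c2cncnc2)cc(C)c1Nc1ccnc(Nc2ccc(C#N)cc2)n1` gives 6800 nM, the lowest of the three numbers so far; compound 1 `Cc1cnc(Nc2ccc(C#N)cc2)nc1Nc1c(F)cc(-c2ccco2)cc1F` gives 8100 nM, within the scatter of compound 3, while compound 2 `Cc1cnc(Nc2ccc(C#N)cc2)nc1Nc1c(F)cc(-c2ccc(C#N)nc2)cc1F` gives 62000 nM, well apart from both. Compound 4 `Cc1cc(-c2ccnc(C(F)(F)F)c2)cc(C)c1Nc1ccnc(Nc2ccc(C#N)cc2)n1` is not yet measured. It differs from compound 3 in one place: 2-(trifluoromethyl)pyridin-4-yl in place of pyrimidin-5-yl on an aromatic carbon. For the measured compounds named here, the single measured step, a 7.7-fold higher number from compound 1 to compound 2 (0.88 log units; beyond the scatter), concerns a different pair of groups on the shared core of compound 1 and therefore bears on the present change only loosely; it shows that exchanging the group on that aromatic carbon can move the half-maximal cytotoxic concentration beyond the scatter, but in which direction the present exchange will go is not told by any measured pair. Going by the values given here, for compound 4 no closer precedent exists. The expectation in this assay is therefore a step of a 1.2-fold lower number from compound 3 to compound 4 (0.09 log units; within the scatter), kept close to compound 3 with a wide range. Compound 4 is estimated in this assay at 5500 nM, with a range from 1800 nM to 20000 nM.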

Compound 4, half-maximal cytotoxic concentration: 6100 nM
Beside the measured number, compound 4's estimate is 1.1-fold (0.04 log units) below it; the measured number falls inside the stated range.
By their numbers in this assay, from the lowest: compounds 4, 3 and 1 (each within the scatter of the next); then compound 2.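

In this assay, the exchange on the aromatic carbon gives a 1.1-fold lower number from compound 3 to compound 4 (0.05 log units; within the scatter), so on the core of compound 3 a group of 10 heavy atoms with a trifluoromethyl can take the place of a group of 6 heavy atoms, with 1 hydrogen-bond acceptor instead of 2, and the number stays within the scatter. Among the compounds shown here, the earlier step on the core of compound 1 (a 7.7-fold higher number from compound 1 to compound 2 (0.88 log units; beyond the scatter)) showed only that an exchange at such a carbon can move the number beyond the scatter, whereas this step shows that a change of aromatic ring need not do so. No measured evidence bears on why the number holds here.

From the compounds shown here alone, whether an amine or a carboxylic acid on this carbon would leave the number within the scatter stays open. Also open, going by these compounds, is whether 6-cyanopyridin-3-yl would bring on the core of compound 3 a step like the one it brought on the core of compound 1.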